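A few compounds are considered here, and "the series" means these few. Any claim that something is new, unique, unknown or untested is made for them only; others in the source may bear on it.

Compound 1 `O=C(O)CCc1ccc(C#Cc2ccnc(Cl)n2)cc1` is built on a core that holds two ring nitrogens and a chloro group. In an in vitro functional assay on 1321-N1 cells for agonist activity at Free fatty acid receptor 1 (Homo sapiens), read by fluorescence, spectrophotometry and calcium flux (a higher number here means a larger maximal response, a lower number a smaller maximal response), compound 1 reaches 131%. Compound 2 `Cc1cnc(Cl)nc1C#Cc1ccc(CCC(=O)O)cc1` differs from it in one place, (methyl in place of hydrogen on an aromatic carbon), and in this assay compound 2 reaches 121%. Compound 3 `O=C(O)CCc1ccc(C#Cc2ccncc2)cc1` rests on a different core; how the two cores differ is not broken down here. In this assay compound 3 reaches 100%, the lowest of the three numbers and beyond the scatter from both others.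

Compound 4 `Cc1cc(C#Cc2ccc(CCC(=O)O)cc2)ccn1` has not been measured yet. It differs from compound 3 by methyl in place of hydrogen on an aromatic carbon. Within the data shown here, this is the same kind of change as the one from compound 1 to compound 2, though the surroundings are not the same: in compound 4 the methyl sits on a six-membered aromatic ring with 1 nitrogen, next to the ring nitrogen and meta to a large group, whereas in compound 2 it sits on a ring with 2 nitrogen, ortho to a large group, two atoms from the ring nitrogen and para to a chloro group. Compound 4 is expected to stay close to compound 3, with an estimated step of no change at the digits printed from compound 3 to compound 4 (within the scatter), because a number 10 percentage points lower from compound 1 to compound 2 (within the scatter) lay within the scatter. Compound 4 is therefore expected to reach about 100% in this assay, most likely between 85% and 115%.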

Compound 4, largest response reached (reported as efficacy), in percent of the reference or control that the assay uses: 102%
For compound 4 the middle estimate is 2 percentage points below the measured one, and the stated range covers the measured number.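

In this assay, putting methyl in place of hydrogen on the core of compound 3 gives a number 2 percentage points higher from compound 3 to compound 4 (within the scatter). Set beside the same change on the other core, the two steps do not differ by more than repeated measurements would be expected to: the same change on two cores in this assay, a number 10 percentage points lower (within the scatter) from compound 1 to compound 2 and a number 2 percentage points higher (within the scatter) from compound 3 to compound 4, 12 percentage points apart, within the scatter of two such steps. Among these compounds, in this small set, then, the methyl change can be carried from one core to the other without a visible shift in the maximal response, but this rests on only two pairs, the methyl sits in a different place on each core, and a maximal response says nothing about the concentration needed to reach it.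

The compounds shown leave open whether a different group in the same place, such as an ethyl, a methoxy or an amine, would also leave the maximal response in place. Also open, as far as these compounds go, is whether a methyl placed elsewhere on these cores would behave the same way.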